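Fluorinated Chain Length and Cytotoxicity in Colon Cancer Cells

The source may report more compounds than this note shows. Statements on the series, on what has been measured and on what is new or still open speak of the compounds shown alone.

Compound 1 `Cc1nc2nc(-c3ccccc3)cc(C(F)(F)F)c2c(=O)n1Cc1cn(CCC(F)(F)C(F)(F)C(F)(F)C(F)(F)C(F)(F)C(F)(F)F)nn1` is the parent of this small set. In a functional assay on COLO 205 cells (Homo sapiens) for cytotoxicity, read by MTT assay, with a stated time of 24 h (on this read-out higher numbers stand for weaker inhibition and lower numbers for stronger inhibition), compound 1 gives > 200 ug/mL, which is a limit of the assay and not a number. Compound 2 `Cc1nc2nc(-c3ccccc3)cc(C(F)(F)F)c2c(=O)n1Cc1cn(CCC(F)(F)C(F)(F)C(F)(F)C(F)(F)C(F)(F)C(F)(F)C(F)(F)C(F)(F)F)nn1` differs from compound 1 by 1,1,2,2,2-pentafluoroethyl in place of fluoro on a saturated chain carbon bound to two fluorine atoms and a saturated chain carbon. In this assay compound 2 gives > 200 ug/mL, again a limit rather than a number. The step that the two limits leave unreadable from compound 1 to compound 2 therefore cannot be sized, since both ends sit at the limit of > 200 ug/mL in this assay, at which 2 of the 3 values shown sit. Compound 3 `CCCCCCc1nc2nc(-c3ccccc3)cc(C(F)(F)F)c2c(=O)n1Cc1cn(CCC(F)(F)C(F)(F)C(F)(F)C(F)(F)C(F)(F)C(F)(F)F)nn1` differs from compound 1 by pentyl in place of hydrogen on a saturated chain carbon bound to an aromatic carbon. In this assay, among the measured compounds shown here, compound 3 gives 132 ug/mL, the only number among the three measured compounds, and the step of an at least 1.5-fold lower number from compound 1 to compound 3 (0.18 log units; that floor lies within the scatter) rests on a limit at one end, so its true size is open.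

Compound 4 `CCCCCCc1nc2nc(-c3ccccc3)cc(C(F)(F)F)c2c(=O)n1Cc1cn(CCC(F)(F)C(F)(F)C(F)(F)C(F)(F)C(F)(F)C(F)(F)C(F)(F)C(F)(F)F)nn1` has not been measured. It differs from compound 3 by 1,1,2,2,2-pentafluoroethyl in place of fluoro on a saturated chain carbon bound to two fluorine atoms and a saturated chain carbon, the same change that separates compound 1 from compound 2, now made on the core of compound 3 rather than that of compound 1. The earlier instance of this change gave no readable step, with both ends at the limit of > 200 ug/mL in this assay, at which 2 of the 3 values shown sit. On that basis the expected step is small: a 1.1-fold higher number from compound 3 to compound 4 (0.06 log units; within the scatter), set beside a step that the two limits leave unreadable from compound 1 to compound 2. Compound 4 is therefore estimated at 150 ug/mL in this assay, with a range from 65 ug/mL to 200 ug/mL, and a real chance that only a limit is reported.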

Compound 4, half-maximal inhibitory concentration: > 200 ug/mL
Compound 4 ended at the assay's limit; the forecaster's own chance of this, stated with the estimate: 40%; middle value at least 1.3-fold (0.12 log units) from the limit.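

In this assay compound 4 gives > 200 ug/mL, which is a limit of the assay and not a number. Carried onto the core of compound 3, the change of fluoro to 1,1,2,2,2-pentafluoroethyl gives an at least 1.5-fold higher number from compound 3 to compound 4 (0.18 log units; that floor lies within the scatter); on this read-out a higher number stands for weaker inhibition, but the step rests on a limit at one end, so only its floor is known and its true size stays open. The result therefore shows no sign that the change lowers the number on this core, yet it does not show that the change has the same size on both cores, since the instance on the core of compound 1 and the step from compound 2 to compound 4 cannot be read, with both ends of each at one limit: the limit of > 200 ug/mL in this assay, at which 3 of the 4 values shown sit.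

The compounds shown leave open whether butyl or octyl in place of pentyl, on the saturated chain carbon bound to an aromatic carbon, would give a number clear of the limit. They also leave open what an amine or a carboxylic acid in place of 1,1,2,2,2-pentafluoroethyl, on the saturated chain carbon bound to two fluorine atoms, would give in this assay.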